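Adding a hydroxy group to compound 3

This account rests on a few compounds, and the source may have more. Where it says the series, first, only, none or still open, it means among the compounds named here.

Measured so far in a physicochemical assay for solubility, in phosphate buffer, with a stated time of 18 h, at pH 7.4; on this read-out higher numbers stand for higher solubility and lower numbers for lower solubility:
- Compound 1 `Nc1nc(-c2ccccn2)nn1-c1ncnc2ccccc12`: 9000 nM
- Compound 2 `COc1cc2ncnc(-n3nc(-c4ccccn4)nc3N)c2cc1N`: 3000 nM
- Compound 3 `COc1ccc2ncnc(-n3nc(-c4ccccn4)nc3N)c2c1`: 7000 nM

On these numbers, compound 3 cannot be told apart from compound 1, and both stand clearly above compound 2. The next compound to consider is compound 4 `COc1cc2c(-n3nc(-c4ccccn4)nc3N)ncnc2cc1O`. It keeps everything in compound 3 and adds hydroxy in place of hydrogen on an aromatic carbon, ortho to a methoxy group (hydroxy in place of hydrogen on an aromatic carbon).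

Among the measured compounds shown here, no measured step adds a hydroxy group, so there is no direct precedent. For the measured compounds named here, the only measured single change is a 1.3-fold lower number from compound 1 to compound 3 (0.11 log units; within the scatter). That change brings in a methoxy group, so it is a loose guide, and it suggests that one small group on this core need not move the number much. Going by the values given here, compound 2, the only measured compound that carries a further group as well as methoxy, gives 3000 nM, a lower number than compound 3 shows. This hints at a small drop in this assay, though perhaps none beyond the scatter.

The estimated step is a 1.4-fold lower number from compound 3 to compound 4 (0.15 log units; within the scatter). Compound 4 is expected at 5000 nM, with an estimated range from 2000 nM to 12000 nM.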

Compound 4, solubility: 44000 nM
For compound 4 the middle estimate is 8.8-fold (0.94 log units) below the measured one; the whole stated range lies below it.
By their numbers in this assay, from the lowest: compound 2; then compounds 3 and 1 (each within the scatter of the next); then compound 4.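

In this assay, hydroxy in place of hydrogen on this aromatic carbon, ortho to a methoxy group, gives a 6.3-fold higher number from compound 3 to compound 4 (0.80 log units; beyond the scatter) and so lies beyond the scatter. Among the compounds shown here, this shows that a single added oxygen atom at this place on the carbon-only ring of the core can shift the number clearly upward, and in the opposite direction to the one earlier step. That earlier change, methoxy in place of hydrogen, gave a 1.3-fold lower number from compound 1 to compound 3 (0.11 log units; within the scatter) and stayed within the scatter, so it offered no sign that a small group on this ring could matter this much, and no measurement at hand explains why this one does.

Still open, going by these compounds, is whether the rise belongs to hydroxy itself, or whether a carboxylic acid, an amine or an ethoxy group on this same carbon would bring a step of similar size. Also open, on these data alone, is whether hydroxy on another carbon of this ring, or hydroxy with no methoxy group ortho to it, would raise the number in the same way.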